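A few compounds are considered here, and "the series" means these few. Any claim that something is new, unique, unknown or untested is made for them only; others in the source may bear on it.

Measured compounds:
compound 1 `COc1ccccc1NC1=CC(=O)c2c(nc3n2[C@H]2OC[C@@H](O)[C@H]2OC3)C1=O`: in a functional assay on MCF7 cells (Homo sapiens) for inhibition, read by sulforhodamine B assay (a higher number here means a weaker inhibitor, a lower number a stronger inhibitor), compound 1 gives 6580 nM
compound 2 `O=C1C(N2CCC2)=CC(=O)c2c1nc1n2[C@H]2OC[C@@H](O)[C@H]2OC1`: for compound 2 this assay reports only a limit, > 16000 nM

Within the data shown here, compound 1 thus holds the only actual number in this assay; the other value is a limit. Among the measured compounds shown here, the one measured step runs an at least 2.4-fold higher number from compound 1 to compound 2 (0.38 log units; beyond the scatter), and it rests on (the limit of > 16000 nM in this assay, at which 1 of the 2 values shown sits), so its size is known only as a lower bound.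

Compound 3 `CCOc1ccccc1NC1=CC(=O)c2c(nc3n2[C@H]2OC[C@@H](O)[C@H]2OC3)C1=O` differs from compound 1 by methyl in place of hydrogen on a saturated chain carbon bound to an oxygen on an aromatic ring. For the measured compounds named here, no measured step touches this part of the molecule: the step from compound 1 to compound 2 replaces the whole (2-methoxyphenyl)amino group and says nothing about lengthening the chain on its oxygen. With no comparable change in hand, no step beyond the scatter is expected; the estimated step is a 1.1-fold lower number from compound 1 to compound 3 (0.04 log units; within the scatter). Compound 3 is expected to give about 6000 nM in this assay, within a range of 2000 nM to 18000 nM.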

Compound 3, half-maximal inhibitory concentration: > 4000 nM
Compound 3: only a limit was reported (the forecaster's own chance of this, stated with the estimate: 20%); the middle value is on the limit's open side.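

In this assay compound 3 gives only a limit, > 4000 nM. Among these compounds, no step from compound 1 to compound 3 can be read from it. The compounds shown leave open whether methoxy to ethoxy changes the number in this assay at all, and in which direction.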